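Phenyl to naphthalen-2-yl in compound 3

The source may hold more compounds than are shown below. What is called first, only, known or untested is meant among the compounds shown, and "the series" means these compounds.

Measured in a functional assay on L1210 cells (Mus musculus) for inhibition; a higher number here means a weaker inhibitor, a lower number a stronger inhibitor:
- compound 1 `CC(=O)CC1C[C@@H](CCCCCCCC#C[C@@H](O)COCCOC[C@@H](O)c2ccccc2)OC1=O`: 19800 nM
- compound 2 `CC(=O)CC1C[C@@H](CCCCCCCC#C[C@@H](O)COCCOC[C@@H](O)N2CCCCC2)OC1=O`: 28700 nM
- compound 3 `CC(=O)CC1C[C@@H](CCCCCCCC#C[C@H](O)COCCOC[C@H](O)c2ccccc2)OC1=O`: 21600 nM

Compound 3 lies within the scatter of both other compounds, so these three values cannot be ranked. Compound 4 `CC(=O)CC1C[C@@H](CCCCCCCC#C[C@H](O)COCCOC[C@H](O)c2ccc3ccccc3c2)OC1=O` carries naphthalen-2-yl in place of the phenyl of compound 3: naphthalen-2-yl in place of phenyl on a saturated chain carbon bound to an oxygen on a saturated carbon and a saturated chain carbon. For the measured compounds named here, two measured steps bear on this change. Replacing that same phenyl with piperidin-1-yl gave a 1.4-fold higher number from compound 1 to compound 2 (0.16 log units; within the scatter), and changing two stereocentres gave a 1.1-fold higher number from compound 1 to compound 3 (0.04 log units; within the scatter). Going by the values given here, no measured compound carries naphthalen-2-yl, so this guide is indirect. Given those two small steps, no change beyond the scatter is expected in this assay, and the expected step is a 1.2-fold lower number from compound 3 to compound 4 (0.08 log units; within the scatter). Compound 4 is estimated at 18000 nM, with an expected range from 7000 nM to 40000 nM.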

Compound 4, half-maximal inhibitory concentration: 3000 nM
Estimate against measurement, compound 4: 6.0-fold (0.78 log units) above; the whole stated range lies above it.
By their numbers in this assay, from the lowest: compound 4; then compounds 1, 3 and 2 (each within the scatter of the next).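

In this assay, naphthalen-2-yl in place of phenyl gives a 7.2-fold lower number from compound 3 to compound 4 (0.86 log units; beyond the scatter). For the compounds shown here, the earlier changes had all stayed within the scatter, so this is the first sign that the group at this position can alter inhibition, and that a larger aromatic group, with two six-membered rings rather than one, can strengthen it. Nothing given here explains the step.

Open, going by these compounds, is whether naphthalen-1-yl or quinolin-3-yl would keep this stronger inhibition. Also open, on these data alone, is whether naphthalen-2-yl acts the same with the stereocentres drawn as in compound 1.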